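The source may hold more compounds than are shown below. What is called first, only, known or untested is meant among the compounds shown, and "the series" means these compounds.

Working notes on the naphthyloxyacetyl hydrazone series.

Three compounds carry numbers in an ADME assay on HEL cells (Homo sapiens) for cytotoxicity; on this read-out lower numbers stand for higher toxicity in this test and higher numbers for lower toxicity in this test. Compound 1 `COc1cc(/C=N/NC(=O)COc2cccc3ccccc23)cc(OC)c1OC` gives 47.9 ug/mL. Compound 2 `Cc1ccc(/C=N/NC(=O)COc2cccc3ccccc23)cc1` gives 80.1 ug/mL. Compound 3 `C/C(=N\NC(=O)COc1cccc2ccccc12)c1ccc(O)cc1` gives 11.1 ug/mL. Compound 2 stands at the highest of the three numbers; compound 1 lies within the scatter of it, so the two cannot be ordered, while compound 3 sits clearly lower and beyond the scatter, so compound 3 is the more toxic of that pair.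

Compound 4 `O=C(COc1cccc2ccccc12)N/N=C/C=C/c1ccccc1` is not yet measured. It differs from compound 2 in one place: 2-phenylethenyl in place of 4-methylphenyl on a carbon with a double bond to nitrogen

Going by the values given here, no measured pair shows this kind of change, so there is no step from which to read a direction. The three numbers shown all fall in a fairly narrow band, and nothing in them points one way for compound 4. The step from compound 2 to compound 4 is therefore expected to be small, likely none beyond the scatter, at a 1.6-fold lower number from compound 2 to compound 4 (0.20 log units; within the scatter). For compound 4 the estimated value in this assay is 50 ug/mL, with a range from 20 ug/mL to 120 ug/mL.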

Compound 4, half-maximal cytotoxic concentration: 100 ug/mL
Compound 4: middle estimate off by 2.0-fold (0.30 log units), on the low side; the range from low to high includes it.
By their numbers in this assay, from the lowest: compound 3; then compounds 1, 2 and 4 (each within the scatter of the next, the first and the last beyond it).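

Going by these compounds alone, at the carbon with a double bond to nitrogen, 2-phenylethenyl in place of 4-methylphenyl gives a 1.2-fold higher number from compound 2 to compound 4 (0.10 log units; within the scatter) in this assay, the first step that can be read at this place. The six-membered aromatic ring stays in the incoming group, but a double bond outside aromatic rings now comes with it, and this exchange leaves the read-out within the scatter. No measurement at hand bears on the cause of this result.

On these data alone, it remains open whether an amine, a carboxylic acid or a longer chain on this carbon would also stay within the scatter of compound 2. Within the data shown here, compound 3 differs from the other compounds in more than one place, so no step to it can be read, and its number cannot be assigned to any single group.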